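Methyl for Chloro on Two Differently Joined Amine Cores

This account rests on a few compounds, and the source may have more. Where it says the series, first, only, none or still open, it means among the compounds named here.

Compound 1 `Clc1cc(N2CC[C@H]3CN[C@H]3C2)cnc1Cl`: 12 nM
Compound 2 `Cc1cc(N2CC[C@H]3CN[C@H]3C2)cnc1Cl`: 7.2 nM
Compound 3 `Clc1cc(N2C[C@@H]3CCNC[C@@H]32)cnc1Cl`: 271 nM

The three measured compounds were tested in a functional assay on HEK293 cells for agonist activity at Neuronal acetylcholine receptor; alpha4/beta2 (Homo sapiens), read by FLIPR; a higher number here means that more compound is needed for the effect, a lower number that less compound is needed. Compound 2 differs from compound 1 by methyl in place of chloro on an aromatic carbon. That change made the step of a 1.7-fold lower number from compound 1 to compound 2 (0.22 log units; within the scatter), so the two values cannot be told apart with confidence.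

Compound 3 is built from the same atoms as compound 1, joined differently; the difference between the two cores is not broken down here. In this assay compound 3 gives 271 nM, a number that stands well beyond the scatter above both compound 1 and compound 2.

Compound 4 `Cc1cc(N2C[C@@H]3CCNC[C@@H]32)cnc1Cl` has not yet been measured. It differs from compound 3 by methyl in place of chloro on an aromatic carbon, the same change that led from compound 1 to compound 2, made at the same place on the ring. Because a 1.7-fold lower number from compound 1 to compound 2 (0.22 log units; within the scatter) stayed within the scatter, the expected step here is a 1.5-fold lower number from compound 3 to compound 4 (0.18 log units; within the scatter). On that basis compound 4 is expected to give 180 nM in this assay, with a likely range from 60 nM to 550 nM.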

Compound 4, half-maximal effective concentration: 76.1 nM
Compound 4: the middle estimate sits 2.4-fold (0.37 log units) above what was measured, and the stated range covers the measured number.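

Methyl in place of chloro on an aromatic carbon gave a 3.6-fold lower number from compound 3 to compound 4 (0.55 log units; beyond the scatter) in this assay. Set beside the same change on the core of compound 1, this step does not differ in size beyond what two such steps would show by chance: the same change on two cores in this assay, a 1.7-fold lower number (0.22 log units; within the scatter) from compound 1 to compound 2 and a 3.6-fold lower number (0.55 log units; beyond the scatter) from compound 3 to compound 4, 2.1-fold (0.33 log units) apart, within the scatter of two such steps. Among these compounds, the change therefore carried over between these two cores with no difference that can be told apart, and the direction of the number was the same on both, but only the step on the core of compound 3 lies beyond the scatter, and two cores cannot show whether the change would carry to any further core or why it behaves as it does.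

From the compounds shown here alone, only chloro and methyl appear at this place on the ring, so it remains open how an amine, a methoxy group or a nitrile there would read on either core. Going by these compounds, whether the step would hold for a longer chain, such as ethyl, also remains open.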